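This account rests on a few compounds, and the source may have more. Where it says the series, first, only, none or still open, it means among the compounds named here.

Measured so far:
- compound 1, `O=C(NCCO)c1cccc2c1CCN2c1cc(Cc2cc(F)cc(C(F)(F)F)c2)ncn1`: 136%
- compound 2, `O=C(NCCO)c1cccc2c1CCN2c1cc(Cc2cccc(F)c2)ncn1`: 148%

Among the compounds with values here, in a functional assay on HEK293 cells for agonist activity at G-protein coupled receptor 52 (Homo sapiens), read by cAMP accumulation, with a stated time of 15 min (on this read-out higher numbers stand for larger maximal responses and lower numbers for smaller maximal responses), compound 2 gives the highest of the two numbers, with compound 1 as its only neighbour; the step of a number 12 percentage points higher from compound 1 to compound 2 (beyond the scatter) shows that losing the trifluoromethyl group from compound 1 went together with a larger maximal response in compound 2. Compound 3, `O=C(NCCO)c1cccc2c1CCN2c1cc(Cc2cccc(OC(F)(F)F)c2)ncn1`, is built from compound 2 by one change: trifluoromethoxy in place of fluoro on an aromatic carbon. Within the data shown here, the single measured step concerns the same carbon ring but a different group: there, trifluoromethyl gave way to hydrogen. Here, fluoro gives way to trifluoromethoxy, and no measured pair shows that exact exchange, so the step from compound 1 to compound 2 only hints that a bulkier fluorinated group on this ring went with a somewhat lower maximal response. On that slender basis a small to modest downward step is expected for compound 3, a number 13 percentage points lower from compound 2 to compound 3 (beyond the scatter), which may well lie within the scatter. The value of compound 3 in this assay is therefore estimated at 135%, between 110% and 160%.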

Compound 3, largest response reached (Emax), in percent of the reference or control that the assay uses: 113%
The estimate for compound 3 lay 22 percentage points above the measured number, within the range that was stated.
By their numbers in this assay, from the lowest: compound 3; then compound 1; then compound 2.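

In this assay, swapping a single fluoro for trifluoromethoxy on the carbon-only aromatic ring, meta to a large group, goes with a large fall, a number 35 percentage points lower from compound 2 to compound 3 (beyond the scatter). This is a bigger change than the modest one seen so far on this ring, which shows that the maximal response depends strongly on the group at this carbon and is not merely nudged by it. The ring of compound 1, which carries both fluoro and trifluoromethyl, also keeps a larger response than the 3-(trifluoromethoxy)phenyl ring, a number 23 percentage points lower from compound 1 to compound 3 (beyond the scatter), so the three rings now form a clear order in which 3-fluorophenyl stands highest, but no measurement offered here accounts for that order.

The compounds shown leave open whether the lower response goes with the oxygen link or with the fluorines of trifluoromethoxy, a question that a methoxy group on the same carbon would bear on. They also leave open how this carbon responds to a group of a different kind, such as an amine or a carboxylic acid.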